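Allyloxy in place of pentylsulfanyl: expected step

A few compounds are considered here, and "the series" means these few. Any claim that something is new, unique, unknown or untested is made for them only; others in the source may bear on it.

In a functional assay on HFF cells (Homo sapiens) for cytotoxicity (a higher number here means that more compound is tolerated, a lower number that less compound is tolerated), compound 3 `CCCCCSc1nc(N)nc2c1ncn2/C=C1/C[C@@H]1CO` gives 215000 nM, within the scatter of compound 1 `CCCSc1nc(N)nc2c1ncn2/C=C1/C[C@@H]1CO` at 283000 nM. Compound 2 `CCCOc1nc(N)nc2c1ncn2/C=C1/C[C@@H]1CO` has the lowest number of the three at 69400 nM. Compound 4 `C=CCOc1nc(N)nc2c1ncn2/C=C1/C[C@@H]1CO` carries allyloxy in place of pentylsulfanyl on an aromatic carbon. Lengthening the sulfur-linked chain gave a 1.3-fold lower number from compound 1 to compound 3 (0.12 log units; within the scatter). The changes between sulfur-linked and oxygen-linked chains were larger, with a 4.1-fold lower number from compound 1 to compound 2 (0.61 log units; beyond the scatter) and a 3.1-fold higher number from compound 2 to compound 3 (0.49 log units; beyond the scatter). Allyloxy is oxygen-linked, like the propoxy of compound 2 , so a modest step down of similar size is expected in this assay. The expected change is a 3.0-fold lower number from compound 3 to compound 4 (0.48 log units; beyond the scatter). Compound 4 is estimated at 72000 nM, with an expected range of 30000 nM to 170000 nM.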

Compound 4, half-maximal cytotoxic concentration: 220000 nM
Beside the measured number, compound 4's estimate is 3.1-fold (0.49 log units) below it; measured number above the stated range.
By their numbers in this assay, from the lowest: compound 2; then compounds 3, 4 and 1 (each within the scatter of the next).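

An oxygen link on this aromatic carbon does not by itself lower the number in this assay: vinyl in place of ethyl gives a 3.2-fold higher number from compound 2 to compound 4 (0.50 log units; beyond the scatter), so among these chains the low number stays with propoxy alone. Allyloxy is not separated from the sulfur-linked chains, with a 1.0-fold higher number from compound 3 to compound 4 (0.01 log units; within the scatter) and a 1.3-fold lower number from compound 1 to compound 4 (0.11 log units; within the scatter). No measured evidence accounts for this difference between the two oxygen-linked chains.

From the compounds shown here alone, whether the low number is peculiar to propoxy stays open. A pentyloxy chain or an amine on the same aromatic carbon would test this.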